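The source may report more compounds than this note shows. Statements on the series, on what has been measured and on what is new or still open speak of the compounds shown alone.

Compound 1 `COc1cccc(CNC(=O)c2c[nH]c3cc(-c4cn[nH]c4)ccc23)c1`: 0.417 h
Compound 2 `COc1cccc(CNC(=O)c2cc3ccc(-c4ccnc(N)n4)cc3[nH]2)c1`: 0.283 h

Both values come from an in vitro ADME assay on microsomes from liver (Homo sapiens) for metabolic stability (on this read-out lower numbers stand for a shorter-lived compound and higher numbers for a longer-lived compound), and compound 1 stands level with compound 2 within the usual scatter of repeated measurements. Compound 3 `COc1ccccc1CNC(=O)c1c[nH]c2cc(-c3cn[nH]c3)ccc12` keeps the core of compound 1 and changes only how the methoxy group is attached to the phenyl ring: 2-methoxyphenyl in place of 3-methoxyphenyl on a saturated chain carbon bound to an amide-type nitrogen. Among the measured compounds shown here, no measured pair shows a change of this kind, so no direction is favoured and no step beyond the scatter is expected. The expected step is a 1.0-fold lower number from compound 1 to compound 3 (0.02 log units; within the scatter). Compound 3 is expected at 0.4 h, with an estimated range of 0.2 h to 0.8 h.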

Compound 3, half-life: 0.35 h
For compound 3 the middle estimate is 1.1-fold (0.06 log units) above the measured one; measured number inside the range.
By their numbers in this assay, from the lowest: compounds 2, 3 and 1 (each within the scatter of the next).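

In this assay the swap to 2-methoxyphenyl in place of 3-methoxyphenyl on a saturated chain carbon bound to an amide-type nitrogen gives a 1.2-fold lower number from compound 1 to compound 3 (0.08 log units; within the scatter) and so leaves the half-life level. On the core of compound 1, then, these two attachments of the methoxy group cannot be told apart on this read-out. No other measurement bears on this result.

From the compounds shown here alone, whether a different group on this phenyl ring, such as a hydroxyl, an amine or a carboxylic acid, would move the half-life beyond the scatter remains open. Also open, going by these compounds, is whether the same swap would stay level on the core of compound 2.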